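Bromoacrylamide Thiazolidinediones Tested for Cytotoxicity

A few compounds are considered here, and "the series" means these few. Any claim that something is new, unique, unknown or untested is made for them only; others in the source may bear on it.

Of the compounds shown here, three have so far been measured in a functional assay on CCRF-CEM cells (Homo sapiens) for cytotoxicity, read by cell counting, with a stated time of 3 days; a lower number here means a stronger inhibitor, a higher number a weaker inhibitor. Compound 3 `C=C(Br)C(=O)Nc1cccc(/C=C2\SC(=O)N(Cc3ccc(F)cc3)C2=O)c1` gives 680 nM, compound 1 `C=C(Br)C(=O)Nc1cccc(/C=C2\SC(=O)N(Cc3cccc(Cl)c3)C2=O)c1` gives 1400 nM, and compound 2 `C=C(Br)C(=O)Nc1ccc(/C=C2\SC(=O)N(Cc3ccc(F)cc3)C2=O)cc1` gives 2400 nM. Compound 1 differs from compound 3 by 3-chlorophenyl in place of 4-fluorophenyl on a saturated chain carbon bound to an amide-type nitrogen in a ring, and this change gave a 2.1-fold higher number from compound 3 to compound 1 (0.31 log units; beyond the scatter). Compound 2 and compound 3 are built from the same atoms joined differently, and the difference between the two cores is not broken down here. The number of compound 2 lies within the scatter of that of compound 1 and beyond the scatter from that of compound 3.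

Compound 4 `C=C(Br)C(=O)Nc1ccc(/C=C2\SC(=O)N(Cc3cccc(Cl)c3)C2=O)cc1` has not yet been measured in this assay. It differs from compound 2 by 3-chlorophenyl in place of 4-fluorophenyl on a saturated chain carbon bound to an amide-type nitrogen in a ring, the same change, at the same place, as that from compound 3 to compound 1, so that this change occurs twice among the compounds shown. Because the earlier instance gave a 2.1-fold higher number from compound 3 to compound 1 (0.31 log units; beyond the scatter), a step of similar size is expected from compound 2 to compound 4, namely a 2.1-fold higher number from compound 2 to compound 4 (0.32 log units; beyond the scatter). Compound 4 is therefore estimated to give 5000 nM, with a likely range from 2000 nM to 12000 nM.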

Compound 4, half-maximal inhibitory concentration: 3700 nM
Compound 4: middle estimate off by 1.4-fold (0.13 log units), on the high side; low and high end bracket the measured number.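

Carried to the second core in this assay, 3-chlorophenyl in place of 4-fluorophenyl gave a 1.5-fold higher number from compound 2 to compound 4 (0.19 log units; within the scatter), so this step alone does not separate the two compounds. Set beside the earlier instance, the step does not differ measurably between the cores: the same change on two cores in this assay, a 2.1-fold higher number (0.31 log units; beyond the scatter) from compound 3 to compound 1 and a 1.5-fold higher number (0.19 log units; within the scatter) from compound 2 to compound 4, 1.3-fold (0.13 log units) apart, within the scatter of two such steps This shows that the two instances can be read as one step of similar size, but it rests on only two pairs, only one of which lies beyond the scatter, and so it does not establish a fixed step size or show that the change would carry over to any other core.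

All four compounds share the bromoacrylamide group and carry only 4-fluorobenzyl or 3-chlorobenzyl on the amide-type nitrogen in a ring. The compounds shown therefore leave open how the two cores would compare with an unsubstituted benzyl, a longer chain or an amine at that place, and what a plain acrylamide would do in place of the bromoacrylamide.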